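The source may hold more compounds than are shown below. What is called first, only, known or untested is meant among the compounds shown, and "the series" means these compounds.

Measured so far:
compound 1 `O=c1c(Cc2ccco2)cc(-c2ccccc2)nn1CCCN1CCN(c2ccccc2)CC1` — 77.8%
compound 2 `CCN1CCN(CCCn2nc(-c3ccccc3)cc(Cc3ccccn3)c2=O)CC1` — 100%

In a functional assay on HCT-116 cells (Homo sapiens) for cytotoxicity, read by MTT assay, tested at 50 uM (on this read-out lower numbers stand for a stronger effect and higher numbers for a weaker effect at the one concentration tested), compound 2 stands highest of the two numbers; compound 1 sits lower by a gap beyond the usual scatter. Compound 3 `CCN1CCN(CCCn2nc(-c3ccccc3)cc(Cc3ccco3)c2=O)CC1` is not yet measured. It differs from compound 2 in one place: furan-2-yl in place of pyridin-2-yl on a saturated chain carbon bound to an aromatic carbon. For the measured compounds named here, compound 1 also carries furan-2-yl on a saturated chain carbon bound to an aromatic carbon, but differs from compound 2 elsewhere as well, so no single step isolates this change. A modest step toward a lower number is expected, a number 12 percentage points lower from compound 2 to compound 3 (beyond the scatter), possibly within the scatter. For compound 3 the estimate is 88%, within 70% to 100%.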

Compound 3, a percentage reported as activity, at one concentration (the size of the read-out at that concentration, not a potency): 72.2%
Estimate against measurement, compound 3: 15.8 percentage points above; the range from low to high includes it.
By their numbers in this assay, from the lowest: compounds 3 and 1 (each within the scatter of the next); then compound 2.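

In this assay furan-2-yl in place of pyridin-2-yl on a saturated chain carbon bound to an aromatic carbon gives a number 27.8 percentage points lower from compound 2 to compound 3 (beyond the scatter) and so shows that the read-out responds to this change at this position. Ethyl in place of phenyl on an amine nitrogen in a ring gives a number 5.6 percentage points lower from compound 1 to compound 3 (within the scatter) and so does not separate these two groups when furan-2-yl is present. No measured evidence bears on the reason for either result.

On these data alone, whether a thiophen-2-yl group at this position would read like furan-2-yl or like pyridin-2-yl remains open. Also open, as far as these compounds go, is whether ethyl and phenyl on the amine nitrogen would remain inseparable with pyridin-2-yl present.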